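Adding a Chloro Group to the Phenyl Ring of Compound 3

This account rests on a few compounds, and the source may have more. Where it says the series, first, only, none or still open, it means among the compounds named here.

Compound 3 `N#Cc1c(-c2ccccc2)nc(SCC(=O)Nn2c(COc3ccc(Cl)cc3Cl)nc3ccccc3c2=O)n(Cc2ccccc2)c1=O` stands second highest of three in a functional assay on the whole organism (strain albino) for inhibition, with Rattus norvegicus as the target, read by paw edema, with a stated time of 1 h, at a dose of 100 mg/kg by the oral route (on this read-out higher numbers stand for more inhibition at the one dose given (going by the name of the read-out) and lower numbers for less inhibition), with 77.3%. Compound 1 `N#Cc1c(-c2ccccc2)nc(SCC(=O)Nn2c(COc3ccc(Cl)cc3Cl)nc3ccccc3c2=O)[nH]c1=O` gives 81.8%, and the step of a number 4.5 percentage points lower from compound 1 to compound 3 (within the scatter) lies within the scatter. Compound 2 `Cn1c(SCC(=O)Nn2c(COc3ccc(Cl)cc3Cl)nc3ccccc3c2=O)nc(-c2ccccc2)c(C#N)c1=O` gives 54.6%, and the step of a number 22.7 percentage points higher from compound 2 to compound 3 (beyond the scatter) is modest but beyond the scatter.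

Compound 4 `N#Cc1c(-c2ccc(Cl)cc2)nc(SCC(=O)Nn2c(COc3ccc(Cl)cc3Cl)nc3ccccc3c2=O)n(Cc2ccccc2)c1=O` differs from compound 3 by chloro in place of hydrogen on an aromatic carbon. Among the compounds with values here, every measured step changes the group on the aromatic nitrogen, not the phenyl ring, so no step speaks directly to this change. With nothing pointing either way, a step within the scatter is expected. Compound 4 is therefore expected to give about 75%, between 60% and 88%, because compound 3 gives 77.3%. That estimate means a number 2.3 percentage points lower from compound 3 to compound 4 (within the scatter).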

Compound 4, a percentage reported as inhibition, in the whole organism at one dose (the size of the read-out at that dose, not a potency): 72.7%
Compound 4: the middle estimate sits 2.3 percentage points above what was measured, within the range that was stated.
By their numbers in this assay, from the lowest: compound 2; then compounds 4, 3 and 1 (each within the scatter of the next).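

In this assay the change from phenyl to 4-chlorophenyl gives a number 4.6 percentage points lower from compound 3 to compound 4 (within the scatter). Within the data shown here, this is the first change on the phenyl ring rather than on the aromatic nitrogen, and it shows that with a benzyl group on that nitrogen, chloro at this place on the ring leaves the reading indistinguishable from that of hydrogen. Nothing here gives a measured reason for this result.

Going by these compounds, whether a methoxy group, an amine or a carboxylic acid at the same place would also leave the reading unchanged stays open. So does whether chloro would do the same with hydrogen or methyl on the aromatic nitrogen.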